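Cytotoxicity in the benzyl thioether series: removing the methyl

The compounds below may be only part of what the source reports. "The series", "measured", "known", "first", "only" and "open" are said of these compounds alone.

Measured so far in an ADME assay on cells (Mus musculus, strain BALB/c) for cytotoxicity, read by MTT assay, with a stated time of 24 h; on this read-out lower numbers stand for higher toxicity in this test and higher numbers for lower toxicity in this test:
- compound 1 `COc1cc(-c2nnc(SCc3ccc([N+](=O)[O-])cc3)o2)ccc1O` gives 688000 nM
- compound 2 `COc1cc(-c2nnc(SCc3c(F)cccc3F)o2)ccc1O` gives 575000 nM
- compound 3 `COc1cc(-c2nnc(SCc3ccccc3C)o2)ccc1O` gives 592000 nM

All three compounds share the same core and differ only in the group on the saturated chain carbon bound to a sulfur. Among the compounds with values here, the spread across them is narrow: the only single-place step, a 1.0-fold higher number from compound 2 to compound 3 (0.01 log units; within the scatter), is within the scatter, and compound 1 lies within the scatter of both compound 2 and compound 3. Compound 3 therefore stands in the middle of a flat set, indistinguishable from its neighbours in this assay.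

Compound 4 `COc1cc(-c2nnc(SCc3ccccc3)o2)ccc1O` is not yet measured. It differs from compound 3 by hydrogen in place of methyl on an aromatic carbon, that is, the 2-methylphenyl becomes phenyl. The step that bears on this is the 2,6-difluorophenyl to 2-methylphenyl exchange, which gave a 1.0-fold higher number from compound 2 to compound 3 (0.01 log units; within the scatter), and the wider comparison across compound 1, compound 2 and compound 3 also shows no change beyond the scatter. Since three different groups at this position give the same number within the scatter, the methyl is not expected to matter either, and the expected step is a 1.0-fold higher number from compound 3 to compound 4 (0.01 log units; within the scatter). Compound 4 is therefore estimated at 600000 nM, with a range of 300000 nM to 1200000 nM in this assay.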

Compound 4, half-maximal cytotoxic concentration: 211000 nM
Compound 4: middle estimate off by 2.8-fold (0.45 log units), on the high side; measured number below the stated range.
By their numbers in this assay, from the lowest: compound 4; then compounds 2, 3 and 1 (each within the scatter of the next).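

Removing the methyl does change the number at this position in this assay: the phenyl of compound 4 reads as more toxic in this test (a 2.8-fold lower number from compound 3 to compound 4 (0.45 log units; beyond the scatter)), and the same holds against the two other substituted rings (a 2.7-fold lower number from compound 2 to compound 4 (0.44 log units; beyond the scatter); a 3.3-fold lower number from compound 1 to compound 4 (0.51 log units; beyond the scatter)). Among the listed compounds, the divide therefore lies between a ring with a group, whether 2-methyl, 2,6-difluoro or nitro, and the ring with hydrogen alone, while the choice among those three groups leaves the numbers within the scatter of each other. Nothing at hand explains this difference.

Open, on these data alone, is whether a ring bearing an amine or a carboxylic acid would stay level with compound 3 or move towards compound 4. Also open, as far as these compounds go, is whether a longer chain in place of the methyl would do the same.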